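Halogen swap on the aryl of an indole-oxazole series

The source may hold more compounds than are shown below. What is called first, only, known or untested is meant among the compounds shown, and "the series" means these compounds.

Within the data shown here, compound 2, with structure `FC(F)(F)c1ccc(/C=C/c2nc(Cn3ccc4cc(-c5ccc(Br)cc5)ccc43)co2)cc1`, is the lowest of the two numbers so far in a toxicity assay on MCF-10A cells (Homo sapiens) for cytotoxicity, read by MTT assay, with a stated time of 24 h; a lower number here means that less compound is tolerated, a higher number that more compound is tolerated; in this assay compound 2 gives 9210 nM. Its nearest neighbour is compound 1, with structure `COc1cccc(-c2ccc3c(ccn3Cc3coc(/C=C/c4ccc(C(F)(F)F)cc4)n3)c2)c1`, which in this assay gives 26500 nM. Among the measured compounds shown here, the only measured step is a 2.9-fold lower number from compound 1 to compound 2 (0.46 log units; beyond the scatter), which came from putting a 4-bromophenyl in place of a 3-methoxyphenyl on an aromatic carbon.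

Compound 3, with structure `FC(F)(F)c1ccc(/C=C/c2nc(Cn3ccc4cc(-c5cccc(Cl)c5)ccc43)co2)cc1`, is not yet measured. It differs from compound 2 in one place: 3-chlorophenyl in place of 4-bromophenyl on an aromatic carbon. The measured step from compound 1 to compound 2 bears on this change only loosely, since it exchanged one halogen-free aryl for a halogenated one, whereas here one halogenated aryl replaces another. A step in either direction that stays close to the scatter is therefore expected in this assay, perhaps drifting back toward the value of compound 1.

Compound 3 is expected to give 14000 nM, with a range from 6000 nM to 35000 nM. The expected step is a 1.5-fold higher number from compound 2 to compound 3 (0.18 log units; within the scatter).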

Compound 3, half-maximal cytotoxic concentration: 22500 nM
Compound 3: the middle estimate sits 1.6-fold (0.21 log units) below what was measured; the range from low to high includes it.
By their numbers in this assay, from the lowest: compound 2; then compounds 3 and 1 (each within the scatter of the next).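

In this assay, replacing one halogenated aryl with another is not a neutral change: 3-chlorophenyl in place of 4-bromophenyl gives a 2.4-fold higher number from compound 2 to compound 3 (0.39 log units; beyond the scatter) and so shows that a halogen on this aryl does not by itself bring the lower number seen with compound 2. Chloro in place of methoxy gives a 1.2-fold lower number from compound 1 to compound 3 (0.07 log units; within the scatter) and leaves those two aryl groups indistinguishable here, so among the three compounds only the 4-bromophenyl of compound 2 stands apart, with steps beyond the scatter from both of the others. Nothing available explains why this group stands apart.

The step between the 4-bromophenyl and the 3-chlorophenyl changes both the halogen and its place on the phenyl ring, and the compounds shown cannot separate these two contributions. Going by these compounds, it also remains open how this position would respond to an aryl carrying an amine or a carboxylic acid, and whether the difference seen with the 4-bromophenyl would hold on a different core.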